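The compounds below may be only part of what the source reports. "The series", "measured", "known", "first", "only" and "open" are said of these compounds alone.

Three compounds built on the same amide-linked core were tested in an ADME assay on U-87MG ATCC cells for inhibition, with U-87 MG (Homo sapiens) as the target, read by MTT assay; a lower number here means that less compound is tolerated, a higher number that more compound is tolerated. Compound 1 `O=C(NCCC1CCNCC1)c1c[nH]c2cc(-c3ccncc3)ccc12` stops at the limit of the measurement, giving > 10000 nM in this assay. Compound 2 `O=C(NCC1CCNCC1)c1cc2ccc(-c3ccc(OC(F)(F)F)cc3)cc2[nH]1` likewise reaches only a limit, with > 10000 nM. Compound 3 `O=C(NCC1CCNCC1)c1cc2ccc(-c3ccc(CO)cc3)cc2[nH]1`, the starting point of this account, also sits at a limit, giving > 10000 nM. For the measured compounds named here, the step that the two limits leave unreadable from compound 2 to compound 3 cannot be read because the limit of > 10000 nM in this assay, at which 3 of the 3 values shown sit, leaves no pair of numbers to compare, so compound 3 stands at the same limit as the other two and no ordering among them can be drawn.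

Compound 4 `O=C(NCC1CCNCC1)c1cc2ccc(-c3ccc(Oc4ccccc4)cc3)cc2[nH]1` is the untested member, and it differs from compound 3 as follows: phenoxy in place of hydroxymethyl on an aromatic carbon. Going by the values given here, no measured step has a readable size, so none bears a direction onto this change. The step that the limit leaves unreadable from compound 3 to compound 4 is therefore expected to be none beyond the scatter. Compound 4 is expected to give 15000 nM, with a range from 7000 nM to 40000 nM, and most likely to appear again only as a limit.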

Compound 4, half-maximal cytotoxic concentration: > 10000 nM
Compound 4: no number, only a limit; the forecaster's own chance of this, stated with the estimate: 85%; the middle value lies beyond the limit too.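

The steps from compound 3 to compound 4 and from compound 2 to compound 4 cannot be read, because all the compounds shown stop at the same point: the limit of > 10000 nM in this assay, at which 4 of the 4 values shown sit. The compounds shown leave open whether any of them differs from another in this assay.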